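Saturating the Acid Side Chain on a Biaryl Scaffold

The compounds below may be only part of what the source reports. "The series", "measured", "known", "first", "only" and "open" are said of these compounds alone.

Compound 1, `O=C(O)/C=C/c1ccccc1-c1ccc(Cl)c(Cl)c1`: in an assay on HEK293 cells for binding affinity to prostaglandin E2 receptor EP4 subtype (Homo sapiens) (on this read-out lower numbers stand for stronger inhibition and higher numbers for weaker inhibition), compound 1 gives > 10000 nM, which is a limit of the assay and not a number.
Compound 2, `O=C(O)/C=C/c1ccccc1-c1cccc(-c2ccccc2OCc2ccccc2)c1`: in this assay compound 2 gives 1700 nM.

Among the measured compounds shown here, of the two values shown, compound 2 holds the only actual number, while compound 1 sits at the limit of > 10000 nM in this assay, at which 1 of the 2 values shown sits. Compound 3, `O=C(O)CCCc1ccccc1-c1cccc(-c2ccccc2OCc2ccccc2)c1`, differs from compound 2 in one place: 3-carboxypropyl in place of 2-carboxyethenyl on an aromatic carbon. For the measured compounds named here, no pair of measured compounds differs in a single place, so no measured step offers a guide to this change, and the direction has to be judged from the structures alone. The expectation is a step of a 1.5-fold higher number from compound 2 to compound 3 (0.17 log units; within the scatter), that is, a small loss that may well stay within the usual scatter. The estimate for compound 3 in this assay is therefore 2500 nM, with a range from 800 nM to 8000 nM.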

Compound 3, inhibition constant: 2000 nM
Compound 3: the middle estimate sits 1.3-fold (0.10 log units) above what was measured; low and high end bracket the measured number.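

In this assay, 3-carboxypropyl in place of 2-carboxyethenyl on an aromatic carbon, ortho to a large group, gives a 1.2-fold higher number from compound 2 to compound 3 (0.07 log units; within the scatter), so on this read-out the two compounds cannot be told apart. Among the compounds shown here, this is the first single-place comparison at this position, and it shows that the number holds when the group carries 1 double bond outside aromatic rings instead of 2 and 6 heavy atoms instead of 5. Nothing measured here bears on why the change has so little effect.

From the compounds shown here alone, whether a longer chain, or a primary amide in place of the carboxylic acid, would hold the number at this position stays open. Compound 1 gives > 10000 nM, which is a limit of the assay and not a number, and it offers no reading of this change on the core of compound 1.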